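The compounds below may be only part of what the source reports. "The series", "measured", "known", "first", "only" and "open" are said of these compounds alone.

Measured in a functional assay on MCF7 cells (Homo sapiens) for antiproliferative activity, read by sulforhodamine B assay, with a stated time of 48 h; on this read-out higher numbers stand for weaker inhibition of growth and lower numbers for stronger inhibition of growth:
compound 1 `O=C(NCc1cn(Cc2ccc(F)cc2)nn1)c1cn(-c2ccccc2)nc1-c1ccccc1`: 7000 nM
compound 2 `O=C(NCc1cn(Cc2ccc(Cl)cc2)nn1)c1cn(-c2ccccc2)nc1-c1ccccc1`: only a limit, > 100000 nM
compound 3 `COc1cc(Cn2cc(CNC(=O)c3cn(-c4ccccc4)nc3-c3ccccc3)nn2)cc(OC)c1OC`: only a limit, > 100000 nM

Compound 2 stands at the upper edge of what this assay reports: its value is a limit, not a number, and it shares that limit with compound 3 (the limit of > 100000 nM in this assay, at which 2 of the 3 values shown sit). Compound 1 is the only one of the three with a read number. The two readable steps run away from compound 1: an at least 14-fold higher number from compound 1 to compound 2 (1.15 log units; beyond the scatter), and an at least 14-fold higher number from compound 1 to compound 3 (1.15 log units; beyond the scatter). Between the two limit compounds the step is a step that the two limits leave unreadable from compound 2 to compound 3.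

Compound 4 `O=C(NCc1cn(Cc2ccc(Cl)cc2)nn1)c1cn(-c2ccccc2)nc1-c1ccc(F)cc1` differs from compound 2 by fluoro in place of hydrogen on an aromatic carbon, which read one bond further out is phenyl to 4-fluorophenyl. Among the compounds with values here, none of the measured steps touches this phenyl; all three concern the group on the saturated chain carbon bound to the aromatic nitrogen. Within the data shown here, no measured step therefore bears directly on the change from compound 2 to compound 4, and no basis is in hand for expecting a step beyond the scatter. Since compound 2 sits at the limit, compound 4 is expected to sit near it too, the expected step being a number no higher from compound 2 to compound 4 (the limit leaves the size open). The estimate for compound 4 in this assay is 100000 nM, with a range from 20000 nM to 300000 nM.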

Compound 4, concentration for 50% growth inhibition: 130 nM
For compound 4 the middle estimate is 770-fold (2.89 log units) above the measured one; measured number below the stated range.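

In this assay, within the data shown here, the phenyl that none of the earlier steps touched proves to be a highly sensitive place: one fluoro in place of hydrogen, para to a large group, gives an at least 760-fold lower number from compound 2 to compound 4 (2.88 log units; beyond the scatter). The earlier readable steps all ran toward weaker inhibition of growth and all concerned the group on the saturated chain carbon, so this is the first change shown that runs toward stronger inhibition, and it shows that a 4-chlorophenyl on that chain carbon does not by itself rule out strong inhibition of growth. The true size of the step stays unknown and only its lower bound can be read, because compound 2 carries a limit and not a number: the limit of > 100000 nM in this assay, at which 2 of the 4 values shown sit.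

On these data alone, whether the same change on the phenyl would have a similar effect with the 4-fluorophenyl of compound 1 or the 3,4,5-trimethoxyphenyl of compound 3 stays open. Also open, as far as these compounds go, is whether the effect is specific to fluoro or would also appear with chloro, a nitrile or an amine at the same place.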